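The compounds below may be only part of what the source reports. "The series", "measured", "known", "first", "only" and "open" are said of these compounds alone.

Of the compounds shown here, three have been tested so far in a functional assay on A549 cells (Homo sapiens) for antiproliferative activity, read by MTT assay, with a stated time of 48 h; on this read-out higher numbers stand for weaker inhibition and lower numbers for stronger inhibition. Compound 1 `COc1ccc(-c2cncc3[nH]c(=O)n(Cc4cc(OC)c(OC)c(OC)c4)c23)cc1` reports > 20000 nM, which is a limit of the assay and not a number. Compound 2 `COc1ccc(-c2nc3cnccc3n2-c2cc(OC)c(OC)c(OC)c2)cc1O` reports > 20000 nM, which is also a limit. Going by the values given here, compound 3 `COc1ccc(-c2cc3c(cn2)[nH]c(=O)n3-c2cc(OC)c(OC)c(OC)c2)cc1F`, which carries a 3-fluoro-4-methoxyphenyl group, gives 2020 nM, the only actual number among the three.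

Compound 4 `COc1ccc(-c2cc3c(cn2)[nH]c(=O)n3-c2cc(OC)c(OC)c(OC)c2)cc1C` has not yet been measured. It differs from compound 3 in one place: methyl in place of fluoro on an aromatic carbon. This is methyl in place of fluoro on an aromatic carbon, ortho to a methoxy group, giving a 4-methoxy-3-methylphenyl group.

Among the compounds with values here, no measured pair here differs in a single place, so the data offer no direct guide to the size of such a swap. A modest step towards stronger inhibition is expected in this assay, and it may not clear the usual scatter. The expected change is a 1.7-fold lower number from compound 3 to compound 4 (0.23 log units; within the scatter). For compound 4 the estimated value is 1200 nM, with an expected range from 200 nM to 8000 nM.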

Compound 4, half-maximal inhibitory concentration: 1910 nM
Estimate against measurement, compound 4: 1.6-fold (0.20 log units) below; measured number inside the range.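

Putting methyl in place of fluoro on this aromatic carbon, ortho to a methoxy group, gives a 1.1-fold lower number from compound 3 to compound 4 (0.02 log units; within the scatter) in this assay, so this read-out does not tell the two compounds apart. Going by these compounds alone, this is the first direct comparison at this position, and it shows that exchanging 3-fluoro-4-methoxyphenyl for 4-methoxy-3-methylphenyl, one heavy atom for one heavy atom and with no hydrogen-bond donor or acceptor on either group, leaves the result in the same range. Nothing measured here bears on why the two groups read alike.

Still open, from the compounds shown here alone, is whether an amine, a carboxylic acid or a longer chain such as propyl on the same aromatic carbon would move the number beyond the usual scatter. Also open, going by these compounds, is what a plain hydrogen there would read, so neither the fluoro nor the methyl group can yet be said to contribute anything on its own.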